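The compounds below may be only part of what the source reports. "The series", "measured", "known", "first", "only" and "open" are said of these compounds alone.

The compounds measured so far:
- compound 1 `CNC(=O)c1cc(C(=O)NC2CCC2)cn(Cc2ccccn2)c1=O`, giving 2.2
- compound 2 `CNC(=O)c1cccn(Cc2ccccc2)c1=O`, giving 3
- compound 3 `CNC(=O)c1cc(C(=O)NC2CC2)cn(Cc2nccc3[nH]ccc23)c1=O`, giving 1.7

In a physicochemical assay for lipophilicity, at pH 7.4 (a higher number here means a more lipophilic compound, a lower number a more polar compound), compound 3 holds the lowest of the three numbers. Compound 1 is its nearest neighbour, standing higher by an amount beyond the scatter, and compound 2 lies furthest off, higher still. Compound 4 `CNC(=O)c1cc(C(=O)NC2CC2)cn(Cc2cccc3occc23)c1=O` has not yet been measured. It differs from compound 3 in one place: a group of 9 heavy atoms (8 carbon, 1 oxygen; one five-membered aromatic ring with 1 hetero atom, one six-membered aromatic ring of carbon only) in place of a group of 9 heavy atoms (7 carbon, 2 nitrogen; one five-membered aromatic ring with 1 hetero atom, one six-membered aromatic ring with 1 hetero atom), on a saturated chain carbon bound to an aromatic nitrogen. Within the data shown here, since no measured pair shows this change, its effect is not known from the data. Given the value of compound 3 in this assay, 1.7, a rise is expected for compound 4, with a step of about a number 1.30 log units higher from compound 3 to compound 4 (beyond the scatter). Compound 4 is therefore estimated at 3, with a range from 2.4 to 3.6.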

Compound 4, distribution coefficient: 3.4
Estimate against measurement, compound 4: 0.40 log units below; the measured number falls inside the stated range.
By their numbers in this assay, from the lowest: compound 3; then compound 1; then compound 2; then compound 4.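

In this assay, the group on a saturated chain carbon bound to an aromatic nitrogen proves able to shift the number strongly: the change to 1-benzofuran-4-yl gives a number 1.70 log units higher from compound 3 to compound 4 (beyond the scatter) without altering the heavy-atom count of 9. The change also takes the group from 1 hydrogen-bond donor to 0 and replaces both nitrogens with a carbon and an oxygen. Nothing shown accounts for the size of this step. The compounds shown leave open which of these atom changes carries the step, and how an indole, a 1-benzothiophene or a carboxylic acid at this place would read.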